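Tert-butoxy in place of bromo on the series core

A few compounds are considered here, and "the series" means these few. Any claim that something is new, unique, unknown or untested is made for them only; others in the source may bear on it.

Values in a functional assay on MCF7 cells (Homo sapiens) for inhibition, read by MTT assay, with a stated time of 72 h (on this read-out lower numbers stand for stronger inhibition and higher numbers for weaker inhibition), so far:
- compound 1 `CC(C)(C)Oc1ccc(-c2nnc(SCCCN3CCN(c4nc5ccccc5o4)CC3)o2)cc1` gives 94900 nM
- compound 2 `COc1ccc(-c2nnc(SCCCN3CCN(c4nc5ccccc5s4)CC3)o2)cc1` gives 171000 nM
- compound 3 `Brc1ccc(-c2nnc(SCCCN3CCN(c4nc5ccccc5s4)CC3)o2)cc1` gives 96300 nM

Compound 3 (96300 nM) lies within the scatter of both compound 1 and compound 2. Compound 4 `CC(C)(C)Oc1ccc(-c2nnc(SCCCN3CCN(c4nc5ccccc5s4)CC3)o2)cc1` carries tert-butoxy in place of bromo on an aromatic carbon. Among the measured compounds shown here, the only measured step bearing on this swaps methoxy for bromo (a 1.8-fold lower number from compound 2 to compound 3 (0.25 log units; within the scatter)) and stays within the scatter. Compound 1 (94900 nM) already carries tert-butoxy, on a different core. In this assay no step beyond the scatter is therefore expected. The estimated step is a 1.0-fold higher number from compound 3 to compound 4 (0.02 log units; within the scatter) and stays within the scatter. For compound 4 the expected value is 100000 nM (estimated range 50000 nM to 200000 nM).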

Compound 4, half-maximal inhibitory concentration: 89300 nM
The estimate for compound 4 lay 1.1-fold (0.05 log units) above the measured number; the range from low to high includes it.
By their numbers in this assay, from the lowest: compounds 4, 1, 3 and 2 (each within the scatter of the next).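

In this assay, tert-butoxy at this position reads the same within the scatter as bromo (a 1.1-fold lower number from compound 3 to compound 4 (0.03 log units; within the scatter)) and as methoxy (a 1.9-fold lower number from compound 2 to compound 4 (0.28 log units; within the scatter)), so the three groups are not told apart here. With tert-butoxy held fixed, the direct comparison of 1,3-benzothiazol-2-yl with 1,3-benzoxazol-2-yl also stays within the scatter (a 1.1-fold lower number from compound 1 to compound 4 (0.03 log units; within the scatter)). No measurement at hand offers an explanation for these readings.

From the compounds shown here alone, it remains open whether an amine or a carboxylic acid at this position would give a number beyond the scatter. The same question stands for a longer chain there.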